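Swapping chloro for trifluoromethyl on the aryl piperazine

The source may hold more compounds than are shown below. What is called first, only, known or untested is meant among the compounds shown, and "the series" means these compounds.

Measured compounds:
- compound 1, `FC(F)(F)c1cccc(N2CCN(CCCN3CC4CCCCN4C3)CC2)c1`, with 278 nM in an assay on membranes from Cerebral cortex with Alpha-1A adrenergic receptor (Rattus norvegicus) as the target, read by radioligand binding; a lower number here means a stronger inhibitor, a higher number a weaker inhibitor
- compound 2, `Clc1cccc(N2CCN(CCCCN3CC4CCCN4C3)CC2)c1`, with 64.9 nM in this assay

Compound 2 stands lowest of the two numbers; its nearest neighbour is compound 1, whose number is higher by a margin that lies beyond the scatter. Going by the values given here, compound 1 and compound 2 differ in more than one place, so their two values show only that compound 2 is the stronger binder here.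

Compound 3, `FC(F)(F)c1cccc(N2CCN(CCCCN3CC4CCCN4C3)CC2)c1`, follows from compound 2 by the change (trifluoromethyl in place of chloro on an aromatic carbon), that is, trifluoromethyl in place of chloro on an aromatic carbon, meta to a large group.

No single-change comparison in this series tells what such a swap does in this assay. The account expects a small step in the direction of a higher number, probably within the scatter, namely a 1.8-fold higher number from compound 2 to compound 3 (0.27 log units; within the scatter). For compound 3 the expected value is 120 nM, with a range from 45 nM to 320 nM.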

Compound 3, inhibition constant: 240 nM
Beside the measured number, compound 3's estimate is 2.0-fold (0.30 log units) below it; the range from low to high includes it.
By their numbers in this assay, from the lowest: compound 2; then compounds 3 and 1 (each within the scatter of the next).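

In this assay, going by these compounds alone, trifluoromethyl in place of chloro on an aromatic carbon, meta to a large group, gives a 3.7-fold higher number from compound 2 to compound 3 (0.57 log units; beyond the scatter) and so provides the first single-change reading at this position: on this core, the chloro compound holds the lower number, and the swap is not neutral. With trifluoromethyl held constant, exchanging the group on the saturated chain carbon, three bonds along the chain from an amine nitrogen in a ring, gives a 1.2-fold lower number from compound 1 to compound 3 (0.06 log units; within the scatter) and leaves compound 1 and compound 3 indistinguishable. The data offer no measurement that explains the chloro to trifluoromethyl step.

As far as these compounds go, it remains open how fluoro, methoxy or a nitrile on the same aromatic carbon would compare with chloro. Also open, from the compounds shown here alone, is whether the chloro to trifluoromethyl step would have the same size on the core of compound 1.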